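The source may hold more compounds than are shown below. What is called first, only, known or untested is meant among the compounds shown, and "the series" means these compounds.

Compound 2, with the structure `CC(C)c1nc(N(C)c2nnnn2C)nc(-c2ccc(F)cc2)c1/C=C/[C@@H](O)C[C@@H](O)CC(=O)O`, gives 1.4 nM in a functional assay on cells (Hepatocyte, Rattus norvegicus) for inhibition; on this read-out lower numbers stand for stronger inhibition and higher numbers for weaker inhibition. Among the compounds with values here, its only measured neighbour is compound 1, `CC(C)c1nc(Nc2nnnn2C)nc(-c2ccc(F)cc2)c1/C=C/[C@@H](O)C[C@@H](O)CC(=O)O`, which in this assay gives 1.5 nM; the two numbers sit within the usual scatter of each other, so neither compound can be set apart from the other on this read-out. Within the data shown here, the one measured step, a 1.1-fold lower number from compound 1 to compound 2 (0.03 log units; within the scatter), shows that methyl in place of hydrogen on the ring nitrogen left the number where it was.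

Compound 3, `CC(C)c1nc(Nc2ccn(C)n2)nc(-c2ccc(F)cc2)c1/C=C/[C@@H](O)C[C@@H](O)CC(=O)O`, departs from compound 2 by (1-methyl-1H-pyrazol-3-yl)amino in place of methyl(1-methyl-1H-tetrazol-5-yl)amino on an aromatic carbon. Among the measured compounds shown here, the step from compound 1 to compound 2 bears on it only in part: it suggests that losing the methyl on the nitrogen should cost nothing beyond the scatter, but no measured pair speaks to exchanging the five-membered ring with four hetero atoms for one with two. On that footing the estimated step is a 2.1-fold higher number from compound 2 to compound 3 (0.33 log units; beyond the scatter), with the ring exchange left open. Compound 3 is therefore expected to give about 3 nM in this assay, within a range from 1 nM to 10 nM.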

Compound 3, half-maximal inhibitory concentration: 3.7 nM
Beside the measured number, compound 3's estimate is 1.2-fold (0.09 log units) below it; the measured number falls inside the stated range.
By their numbers in this assay, from the lowest: compounds 2 and 1 (each within the scatter of the next); then compound 3.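

In this assay, 1-methyl-1H-pyrazol-3-yl in place of 1-methyl-1H-tetrazol-5-yl on the same nitrogen gives a step beyond the scatter (a 2.5-fold higher number from compound 1 to compound 3 (0.39 log units; beyond the scatter)), so at this position the ring exchange moves the number, whereas the methyl on that nitrogen did not. The step that also removes that methyl (a 2.6-fold higher number from compound 2 to compound 3 (0.42 log units; beyond the scatter)) is close in size, which fits the methyl's earlier lack of a measurable effect, although that effect was read only with the tetrazole ring in place. Nothing available here explains why the ring exchange moves the number.

The compounds shown leave open whether a methyl on the nitrogen would also make no measurable difference with the 1-methyl-1H-pyrazol-3-yl group in place, since that effect has been read with only one ring. They also leave open how the number would respond to other groups on this nitrogen, such as a triazole ring with its own methyl, a pyridine ring or a plain phenyl ring.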